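Amide nitrogen swap on trimethoxyphenyl cyclopropane carboxamides

The source may hold more compounds than are shown below. What is called first, only, known or untested is meant among the compounds shown, and "the series" means these compounds.

Measured compounds:
compound 1 `CCOC(=O)[C@]1(C(=O)Nc2ccccc2)C[C@H]1c1cc(OC)c(OC)c(OC)c1` gives > 100000 nM, a limit of the assay, in a functional assay on QGY cells (Homo sapiens) for cytotoxicity, read by MTT assay, with a stated time of 48 h; a lower number here means a stronger inhibitor, a higher number a weaker inhibitor
compound 2 `CCOC(=O)[C@]1(C(=O)NCc2ccc(C)cc2)C[C@H]1c1cc(OC)c(OC)c(OC)c1` gives 32100 nM in this assay
compound 3 `COc1cc([C@H]2C[C@]2(CO)C(=O)NCc2ccc(C)cc2)cc(OC)c1OC` gives 56100 nM in this assay

Compound 1 and compound 2 share a core and differ by phenyl in place of 4-methylbenzyl on an amide-type nitrogen; the step of an at least 3.1-fold higher number from compound 2 to compound 1 (0.49 log units; beyond the scatter) runs to a limit, recorded as the limit of > 100000 nM in this assay, at which 1 of the 3 values shown sits. Compound 3 carries a different core from compound 2, and the difference between the two cores is not broken down here. Compound 4 `COc1cc([C@H]2C[C@]2(CO)C(=O)Nc2ccccc2)cc(OC)c1OC` is not yet measured in this assay. Compound 4 differs from compound 3 by phenyl in place of 4-methylbenzyl on an amide-type nitrogen, the same change that was made from compound 2 to compound 1, and the place lines read alike for both pairs. Beside the earlier step, the change from compound 3 to compound 4 is expected to give a 3.6-fold higher number from compound 3 to compound 4 (0.55 log units; beyond the scatter) in this assay, resting on compound 2 and compound 1 and their step of an at least 3.1-fold higher number from compound 2 to compound 1 (0.49 log units; beyond the scatter). Compound 4 is therefore estimated at 200000 nM in this assay, with the range from 80000 nM to 500000 nM, and a limit rather than a number is the more likely report.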

Compound 4, half-maximal inhibitory concentration: > 100000 nM
Compound 4 gave a limit, no number; the forecaster's own chance of this, stated with the estimate: 75%; the middle value does not contradict the limit.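

In this assay, phenyl in place of 4-methylbenzyl on an amide-type nitrogen gives an at least 1.7-fold higher number from compound 3 to compound 4 (0.25 log units; that floor lies within the scatter). Compound 4 reads > 100000 nM, which is a limit of the assay and not a number, so this floor is all that can be read on this core, and by itself it does not show a change beyond the scatter. The direction agrees with the earlier step, but agreement in size between the two cores is not shown: the same change on two cores in this assay, an at least 3.1-fold higher number (0.49 log units; beyond the scatter) from compound 2 to compound 1 and an at least 1.7-fold higher number (0.25 log units; that floor lies within the scatter) from compound 3 to compound 4; the limit leaves it open whether they differ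

Neither phenyl compound gives a number, so compound 1 and compound 4 cannot be ranked against each other: the limit of > 100000 nM in this assay, at which 2 of the 4 values shown sit.

Left open is how benzyl or 4-methylphenyl on the amide-type nitrogen would read on either core, which would separate the contribution of the methyl from that of the methylene link. Also open, from the compounds shown here alone, is how an amine or a carboxylic acid in place of the methyl of 4-methylbenzyl would read in this assay.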